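The compounds below may be only part of what the source reports. "The series", "measured", "known", "first", "only" and "open" are said of these compounds alone.

Series notes. Compound 1 `COc1ccc(CN(C(=O)C[Se]C#N)c2cc(OC)c(OC)c(OC)c2)cc1O` is the reference point. In a functional assay on HCT-116 cells (Homo sapiens) for inhibition, read by MTT assay, with a stated time of 48 h (on this read-out higher numbers stand for weaker inhibition and lower numbers for stronger inhibition), compound 1 gives 310 nM, the lowest of the two numbers recorded. Compound 3 `COc1ccc(N(Cc2cc(OC)c(OC)c(OC)c2)C(=O)CN=[N+]=[N-])cc1O` stands nearest, giving 38800 nM in this assay, a gap beyond the usual scatter. Compound 2 `COc1cc(NCc2ccc(Cl)cc2)cc(OC)c1OC` returns only a limit of the assay in this assay, > 80000 nM, and not a number (the limit of > 80000 nM in this assay, at which 1 of the 3 values shown sits). Going by the values given here, no two measured compounds differ in a single place, so no measured step serves as a yardstick.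

Compound 4 `COc1ccc(CN(C(=O)C(C)C)c2cc(OC)c(OC)c(OC)c2)cc1O` is the next candidate. It differs from compound 1 on the carbonyl carbon whose other neighbour is the amide-type nitrogen: a group of 3 heavy atoms (3 carbon; no ring) in place of a group of 4 heavy atoms (2 carbon, 1 nitrogen, 1 selenium; no ring), on a carbonyl carbon. The group that leaves carries the selenium and the triple bond; the isopropyl that enters carries neither. Among the compounds with values here, compound 1 is the only member bearing that selenium group and also the only one with a low number, while compound 3, with a different group on its carbonyl carbon, sits far higher at 38800 nM. On that basis the step from compound 1 to compound 4 in this assay is expected to be a sizeable weakening, a 97-fold higher number from compound 1 to compound 4 (1.99 log units; beyond the scatter). Compound 4 is accordingly expected to give about 30000 nM in this assay, with a likely range of 5000 nM to 80000 nM.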

Compound 4, half-maximal inhibitory concentration: 310 nM
The estimate for compound 4 lay 97-fold (1.99 log units) above the measured number, and the stated range ends above it.
By their numbers in this assay, from the lowest: compounds 1 and 4 (each within the scatter of the next); then compound 3. At a limit, above all of these: compound 2.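

On a carbonyl carbon whose other neighbours are the amide-type nitrogen, this assay gives no change at the digits printed from compound 1 to compound 4 (within the scatter). Going by these compounds alone, the selenium and the triple bond are therefore not required for a number at this level in this pair: the isopropyl of compound 4 carries neither, and the single comparison available at this position shows no separation between the two groups. The data shown give no measured basis for explaining this equivalence, and the one available assay limit does not bear on this pair.

Compound 3 differs from compound 1 and compound 4 in more than one place, so no step can be read from it, and its number cannot be assigned to the group on its carbonyl carbon. The compounds shown leave open how far this tolerance extends, for instance whether a methyl, a longer alkyl chain, a primary amine or a carboxylic acid on the same carbonyl carbon would stay within the scatter of compound 1 or move clearly away from it.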